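The compounds below may be only part of what the source reports. "The series", "measured", "known", "first", "only" and "open" are said of these compounds alone.

Measured in an assay on M10 cells (Gallus gallus) for binding affinity to Neuronal acetylcholine receptor; alpha4/beta2 (Homo sapiens); a higher number here means a weaker inhibitor, a lower number a stronger inhibitor:
- compound 1, `[N-]=[N+]=Nc1cc(Cn2ccsc2=N)cnc1Cl`: 0.47 nM
- compound 2, `[N-]=[N+]=Nc1cncc(Cn2ccnc2N[N+](=O)[O-])c1`: 5400 nM
- compound 3, `[N-]=[N+]=Nc1cc(Cl)ncc1Cn1ccnc1N[N+](=O)[O-]`: 16900 nM

Compound 3 stands at the highest of the three numbers in this assay. Its nearest neighbour is compound 2, whose number lies lower by a margin beyond the scatter, and compound 1 lies far lower still, by a gap well beyond the scatter. Compound 3 is thus the weakest binder of the three on these figures.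

Compound 4, `[N-]=[N+]=Nc1ccncc1Cn1ccnc1N[N+](=O)[O-]`, has not been measured. It differs from compound 3 in one place: hydrogen in place of chloro on an aromatic carbon. For the measured compounds named here, no step between measured compounds covers this change, so its size must be judged from the spread of numbers in this assay. Compound 2 also carries no chloro and gives a number below that of compound 3, which suggests that removing chloro need not raise the number. The change from compound 3 to compound 4 is therefore expected to give a moderate decrease in this assay, of about a 2.8-fold lower number from compound 3 to compound 4 (0.45 log units; beyond the scatter), though a result within the scatter is also possible. Compound 4 is estimated at 6000 nM, with a range from 1500 nM to 25000 nM.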

Compound 4, inhibition constant: 95800 nM
Compound 4: middle estimate off by 16-fold (1.20 log units), on the low side; measured number above the stated range.
By their numbers in this assay, from the lowest: compound 1; then compound 2; then compound 3; then compound 4.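

Read in this assay, replacing chloro with hydrogen on the aromatic carbon next to the ring nitrogen moves the number upward, with a 5.7-fold higher number from compound 3 to compound 4 (0.75 log units; beyond the scatter), a step beyond the scatter. For the compounds shown here, this is the first direct reading of the change at this position, and it shows that, within this pair, chloro at this place, meta to an azido group and para to a large group, goes with the lower number, making compound 3 the stronger binder of the two. Nothing in the data shown bears on what lies behind this step, so it stands as an observation without an explanation.

As far as these compounds go, this single pair gives one reading on one core, so whether the same change would carry over to the core of compound 1, which also carries a chloro group, remains open. Also open, from the compounds shown here alone, is how a fluoro, bromo, methyl or methoxy group on this same aromatic carbon would compare with chloro and hydrogen.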